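The source may hold more compounds than are shown below. What is called first, only, known or untested is meant among the compounds shown, and "the series" means these compounds.

Working notes on the series, read in a functional assay on HT-29 cells (Homo sapiens) for cytotoxicity, read by MTT assay, with a stated time of 72 h; on this read-out lower numbers stand for stronger inhibition and higher numbers for weaker inhibition. Compound 1 `CC(C)(C)OC(=O)N1CCN(c2c(C(=O)NCc3ccc(F)cc3)nc(Br)c3cccnc23)CC1` gives > 10000 nM, which is a limit of the assay and not a number. For compound 3 `N[C@H]1CC[C@H](Nc2c(C(=O)NCc3ccc(F)cc3)nc(N3CCCCC3)c3cccnc23)CC1` the entry is "not determined" (no result reported). For the measured compounds named here, compound 2 `CN(C)CCCNc1c(C(=O)NCc2ccc(F)cc2)nc(Br)c2cccnc12`, at 6000 nM, therefore holds the only number available. Compound 4 `COC(=O)CNc1c(C(=O)NCc2ccc(F)cc2)nc(Br)c2cccnc12` differs from it as follows: methoxycarbonyl in place of 2-(dimethylamino)ethyl on a saturated chain carbon bound to a nitrogen on an aromatic ring. No measured pair sizes this change, so the expectation is loose. A shift toward weaker inhibition, roughly the size of the scatter, is expected, giving an estimated 1.7-fold higher number from compound 2 to compound 4 (0.22 log units; within the scatter). The estimate for compound 4 is 10000 nM, with an expected range of 3500 nM to 30000 nM.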

Compound 4, half-maximal inhibitory concentration: > 10000 nM
Compound 4: only a limit was reported; the forecaster's own chance of this, stated with the estimate: 55%; the middle value lies on the limit itself.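

In this assay, for the compounds shown here, methoxycarbonyl in place of 2-(dimethylamino)ethyl gives the first readable step at this place, an at least 1.6-fold higher number from compound 2 to compound 4 (0.22 log units; that floor lies within the scatter). Compound 4 gives > 10000 nM, which is a limit of the assay and not a number. Only a floor is known, and the true size of the change stays unresolved because the reading stops at this limit: the limit of > 10000 nM in this assay, at which 2 of the 4 values shown sit.

As far as these compounds go, how far the number of compound 4 lies past that floor remains open. Also open, from the compounds shown here alone, is how a carboxylic acid or a longer chain ending in a primary amine would read at this place on the shared core.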